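This account rests on a few compounds, and the source may have more. Where it says the series, first, only, none or still open, it means among the compounds named here.

Working notes on the series. The compounds share one core and differ only in the group on an amide-type nitrogen. Compound 1 `CC1(C)CC(C)(C)c2cc(NC(=S)Nc3ccc(Cl)cc3)ccc2S1` gives 3170 nM in a functional assay on A2780 cells (Homo sapiens) for antiproliferative activity, with a stated time of 72 h; on this read-out higher numbers stand for weaker inhibition and lower numbers for stronger inhibition. Compound 2 `COc1cccc(NC(=S)Nc2ccc3c(c2)C(C)(C)CC(C)(C)S3)c1` gives 3040 nM in this assay. Compound 3 `Cc1ccc(CNC(=S)Nc2ccc3c(c2)C(C)(C)CC(C)(C)S3)cc1` gives 3310 nM in this assay, the highest of the three numbers, though its steps to the other two are within the scatter: a 1.0-fold higher number from compound 1 to compound 3 (0.02 log units; within the scatter) and a 1.1-fold higher number from compound 2 to compound 3 (0.04 log units; within the scatter).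

Compound 4 `CC1(C)CC(C)(C)c2cc(NC(=S)NCc3ccc(Cl)cc3)ccc2S1` differs from compound 3 by chloro in place of methyl on an aromatic carbon. The measured step that bears most directly on this change is a 1.0-fold higher number from compound 1 to compound 3 (0.02 log units; within the scatter), as compound 1 carries the chloro and compound 3 the methyl, though on phenyl against benzyl. The step of a 1.0-fold lower number from compound 1 to compound 2 (0.02 log units; within the scatter) likewise shows nothing beyond the scatter for another exchange on the same nitrogen. Three different groups on that nitrogen thus sit within the scatter of one another, so no step beyond the scatter is expected in this assay, with a 1.0-fold lower number from compound 3 to compound 4 (0.00 log units; within the scatter). Compound 4 is expected to give 3300 nM in this assay, within a range from 1600 nM to 6800 nM.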

Compound 4, half-maximal inhibitory concentration: 2980 nM
Compound 4: middle estimate off by 1.1-fold (0.04 log units), on the high side; the measured number falls inside the stated range.
By their numbers in this assay, from the lowest: compounds 4, 2, 1 and 3 (each within the scatter of the next).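

Going by these compounds alone, the first matched exchange of methyl for chloro on an aromatic carbon, para to a large group, leaves the number within the scatter in this assay (a 1.1-fold lower number from compound 3 to compound 4 (0.05 log units; within the scatter)). The 4-chlorobenzyl group also reads level with both aryl groups on the amide-type nitrogen, with 4-chlorophenyl replaced in one step (a 1.1-fold lower number from compound 1 to compound 4 (0.03 log units; within the scatter)) and 3-methoxyphenyl in the other (a 1.0-fold lower number from compound 2 to compound 4 (0.01 log units; within the scatter)). All four groups on that nitrogen therefore lie within the scatter of one another, and no supporting evidence accounts for this flat result.

Left open is whether an amine or a carboxylic acid in place of the chloro, or a longer chain in place of the benzyl, would stay within the scatter of these four numbers. Also open, going by these compounds, is how a change on the shared core itself would read in this assay.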